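A few compounds are considered here, and "the series" means these few. Any claim that something is new, unique, unknown or untested is made for them only; others in the source may bear on it.

Of the compounds shown here, two sharing one core have so far been tested in a functional assay on MDA-MB-231 cells (Homo sapiens) for cytotoxicity, read by MTT assay, with a stated time of 72 h; a lower number here means a stronger inhibitor, a higher number a weaker inhibitor. Compound 2 `Cn1c(=O)c(C(=O)Nc2ccc(Oc3ccncc3-c3cccnc3)c(F)c2)nn(-c2cccc(C(F)(F)F)c2)c1=O` gives 3980 nM there, while compound 1 `Cn1c(=O)c(C(=O)Nc2ccc(Oc3ccncc3-c3cccnc3)c(F)c2)nn(-c2ccc(Cl)cc2)c1=O` gives 3220 nM; the step of a 1.2-fold higher number from compound 1 to compound 2 (0.09 log units; within the scatter) lies within the scatter, so compound 2 stands level with compound 1 rather than apart from it. Compound 3 `Cn1c(=O)c(C(=O)Nc2ccc(Oc3ccncc3-c3cccnc3)c(F)c2)nn(-c2c(Cl)cccc2Cl)c1=O` carries the change (2,6-dichlorophenyl in place of 3-(trifluoromethyl)phenyl on an aromatic nitrogen). Within the data shown here, the only measured step that bears on this change also swapped the group on that same aromatic nitrogen, and it was a 1.2-fold higher number from compound 1 to compound 2 (0.09 log units; within the scatter). On that basis the expected step in this assay is a 1.1-fold lower number from compound 2 to compound 3 (0.04 log units; within the scatter), nothing beyond the scatter. Compound 3 is therefore estimated at 3600 nM, with a likely range from 1500 nM to 9000 nM.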

Compound 3, half-maximal inhibitory concentration: 9690 nM
Estimate against measurement, compound 3: 2.7-fold (0.43 log units) below; the whole stated range lies below it.
By their numbers in this assay, from the lowest: compounds 1 and 2 (each within the scatter of the next); then compound 3.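

Swapping the group on this aromatic nitrogen can change the result in this assay, which the first two compounds, standing level, did not show. The change to 2,6-dichlorophenyl brings a 2.4-fold higher number from compound 2 to compound 3 (0.39 log units; beyond the scatter) and a 3.0-fold higher number from compound 1 to compound 3 (0.48 log units; beyond the scatter), so compound 3 is a weaker inhibitor than either, though three compounds establish no general pattern. No available evidence explains this difference.

Still open, going by these compounds, is whether other chlorine-bearing phenyl groups behave like 2,6-dichlorophenyl. Also open, on these data alone, is how a phenyl ring carrying an amine or a carboxylic acid, or a longer alkyl chain in its place, would perform.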